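Working notes: chloro to methoxy, compound 2 to compound 3

A few compounds are considered here, and "the series" means these few. Any claim that something is new, unique, unknown or untested is made for them only; others in the source may bear on it.

Measured so far:
- compound 1 `O=C(CN1CCN(c2cc3c(cc2F)c(=O)c(C(=O)O)cn3C2CC2)CC1)Nc1ccc(C(=O)/C=C/c2ccccc2Cl)cc1`: 4.2%
- compound 2 `O=C(CN1CCN(c2cc3c(cc2F)c(=O)c(C(=O)O)cn3C2CC2)CC1)Nc1ccc(C(=O)/C=C/c2ccc(Cl)cc2)cc1`: 0.4%

In an assay on isolated protein for inhibition of DNA topoisomerase 1 (Homo sapiens), with a stated time of 30 min, tested at 20 uM (on this read-out higher numbers stand for a stronger effect at the one concentration tested and lower numbers for a weaker effect), compound 1 gives 4.2% and compound 2 gives 0.4%. Both numbers are small at the single concentration tested. The one measured step, a number 3.8 percentage points lower from compound 1 to compound 2 (within the scatter), stays within the scatter, so compound 2 and compound 1 cannot be told apart on this read-out; compound 2 simply carries the smaller of the two numbers shown.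

Compound 3 `COc1ccc(/C=C/C(=O)c2ccc(NC(=O)CN3CCN(c4cc5c(cc4F)c(=O)c(C(=O)O)cn5C4CC4)CC3)cc2)cc1` is the next member. It differs from compound 2 by methoxy in place of chloro on an aromatic carbon. Among the measured compounds shown here, no measured step exchanges chloro for methoxy, so nothing bears directly on this change; the only step available, the chloro moving within the ring, was within the scatter. With both measured numbers near zero, the step of a number 2.6 percentage points higher from compound 2 to compound 3 (within the scatter) is expected to stay within the scatter. Compound 3 is therefore estimated at 3%, with a range of -6% to 13%.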

Compound 3, a percentage reported as inhibition, at one concentration (the size of the read-out at that concentration, not a potency): 25.3%
Beside the measured number, compound 3's estimate is 22.3 percentage points below it, and the stated range ends below it.
By their numbers in this assay, from the lowest: compounds 2 and 1 (each within the scatter of the next); then compound 3.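

Among the compounds shown here, at this position on the aromatic ring, para to a large group, the exchange of chloro for methoxy gives the first step beyond the scatter in this assay, namely a number 24.9 percentage points higher from compound 2 to compound 3 (beyond the scatter), whereas the step between the two chlorophenyl compounds stayed within it. The comparison with the 2-chlorophenyl compound points the same way, with a number 21.1 percentage points higher from compound 1 to compound 3 (beyond the scatter), so compound 3 stands clear of both chloro compounds. The change replaces one heavy atom with two and adds a hydrogen-bond acceptor, but no supporting data are available to explain the difference.

Going by these compounds, whether the difference follows the oxygen or the added carbon stays open, and a hydroxyl or an amine at this place would help separate the two. Also open, on these data alone, is whether a 2-methoxyphenyl group would give a similar number.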